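Aryl-piperazine amides: anticonvulsant dose of compound 4

This account rests on a few compounds, and the source may have more. Where it says the series, first, only, none or still open, it means among the compounds named here.

Measured so far:
compound 1 `CC1(c2ccccc2)CC(=O)N(CC(=O)N2CCN(c3ccccc3F)CC2)C1=O`: 100 mg/kg
compound 2 `CC1(c2ccccc2)CC(=O)N(CC(=O)N2CCN(c3ccc(Cl)cc3)CC2)C1=O`: 300 mg/kg
compound 3 `Cc1cccc(N2CCN(C(=O)CN3C(=O)CC(C)(c4ccccc4)C3=O)CC2)c1`: "not active" (no number reported)

All three share one core and differ only in the aryl group on the piperazine nitrogen. Going by the values given here, in a functional assay on the whole organism (strain CD-1) with Mus musculus as the target, with a stated time of 0.5 h (a higher number here means that more compound is needed for the effect, a lower number that less compound is needed), compound 1 gives 100 mg/kg, and compound 2 gives 300 mg/kg; the step of a 3.0-fold higher number from compound 1 to compound 2 (0.48 log units; beyond the scatter) is the only measured step. Compound 3 gives "not active" (no number reported) in this assay, so no number is available for it; it stands outside the range covered by compound 1 and compound 2.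

Compound 4 `CC1(c2ccccc2)CC(=O)N(CC(=O)N2CCN(c3cccc(Cl)c3)CC2)C1=O` is not yet measured. It differs from compound 3 by chloro in place of methyl on an aromatic carbon. Among the compounds with values here, no measured step addresses this exchange; the step from compound 1 to compound 2 concerns a different position and a different halogen and so bears only loosely on it. Compound 2, which also carries a chloro on the aryl ring, gives 300 mg/kg, so a result in that region is plausible for compound 4, but the absence of a number for compound 3 leaves a real chance that compound 4 also shows no activity. Compound 4 is expected to give about 300 mg/kg in this assay, in the range 100 mg/kg to 1000 mg/kg.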

Compound 4, minimum effective dose: "not active" (no number reported)
For compound 4 the study gives words and no number, and the estimate cannot be compared.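

In this assay compound 3 gives "not active" (no number reported) and compound 4 gives "not active" (no number reported) so no step can be read for methyl to chloro. Nothing measured here offers an explanation for this result. The compounds shown leave open whether 3-methylphenyl and 3-chlorophenyl differ in effective dose at all.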